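Swapping Morpholin-4-yl for Methylamino on a Carbonyl Carbon

The compounds below may be only part of what the source reports. "The series", "measured", "known", "first", "only" and "open" are said of these compounds alone.

Measured in a functional assay (aorta) with Rattus norvegicus as the target; a lower number here means that less compound is needed, a higher number that more compound is needed for the effect:
- compound 1 `COc1ccc(-c2nc(N=C(N)N)sc2-c2ccc(OC)cc2)cc1`: 2 uM
- compound 2 `COc1ccc(-c2nc(CNC(=O)N3CCOCC3)sc2-c2ccc(OC)cc2)cc1`: 12 uM

Of these two compounds, compound 2 has the higher number, at 12 uM. Compound 3 `CNC(=O)NCc1nc(-c2ccc(OC)cc2)c(-c2ccc(OC)cc2)s1` differs from compound 2 in one group: methylamino in place of morpholin-4-yl on a carbonyl carbon. Methylamino stands in place of morpholin-4-yl on a carbonyl carbon. For the measured compounds named here, only one measured step is available, and it concerns a change elsewhere in the structure: a 6.0-fold higher number from compound 1 to compound 2 (0.78 log units; beyond the scatter). Going by the values given here, that step gives a rough scale for a change of one group, but it shows no direction for this one, and no measured pair varies the group on the carbonyl carbon. No clear shift in this assay is therefore expected, although a step of similar size remains possible. The expected step is a 1.2-fold lower number from compound 2 to compound 3 (0.08 log units; within the scatter). For compound 3 the estimate is 10 uM, with an expected range from 3 uM to 35 uM.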

Compound 3, concentration for half-maximal effect: 15 uM
The estimate for compound 3 lay 1.5-fold (0.18 log units) below the measured number, and the stated range covers the measured number.
By their numbers in this assay, from the lowest: compound 1; then compounds 2 and 3 (each within the scatter of the next).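

In this assay, the exchange of morpholin-4-yl for methylamino on a carbonyl carbon amounts to a 1.3-fold higher number from compound 2 to compound 3 (0.10 log units; within the scatter) and so leaves the number within the scatter, which shows that at this position the ring can give way to the smaller open group with no clear shift. The group on the aromatic carbon as a whole still matters, as a 7.5-fold higher number from compound 1 to compound 3 (0.88 log units; beyond the scatter) stands beyond the scatter, so compound 2 and compound 3 both remain apart from compound 1 with or without the ring. No evidence is available on what lies behind these numbers.

Going by these compounds, whether a longer chain or a carboxylic acid on the carbonyl carbon would shift the number remains open. On these data alone, it is also open whether a simple amine in place of the whole carbonyl-bearing group would bring the number closer to that of compound 1.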